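From Methyl to Isopropyl: Estimating Compound 3

The source may hold more compounds than are shown below. What is called first, only, known or untested is meant among the compounds shown, and "the series" means these compounds.

Measured so far:
Compound 1 `OCCCc1cn(CCNc2nonc2/C(=N/O)Nc2ccc(F)c(Br)c2)nn1` gives 958 nM in an assay on isolated protein for inhibition of Indoleamine 2,3-dioxygenase 2 (Homo sapiens); a higher number here means a weaker inhibitor, a lower number a stronger inhibitor.
Compound 2 `CCC(C)(O)c1cn(CCNc2nonc2/C(=N/O)Nc2ccc(F)c(Br)c2)nn1` gives 958 nM in this assay.

Compound 2 stands level with compound 1 in this assay: the step of no change at the digits printed from compound 1 to compound 2 (within the scatter) lies within the scatter, so swapping 3-hydroxypropyl for 1-hydroxy-1-methylpropyl on the aromatic carbon changed nothing that can be measured.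

Compound 3 `CC(C)CC(C)(O)c1cn(CCNc2nonc2/C(=N/O)Nc2ccc(F)c(Br)c2)nn1` has not yet been measured. It differs from compound 2 by isopropyl in place of methyl on a saturated chain carbon, two bonds along the chain from an aromatic carbon and an oxygen on a saturated carbon. For the measured compounds named here, only one measured step bears on this region, the one from compound 1 to compound 2, and it was flat. That step altered the hydroxyalkyl group considerably without effect, which suggests this part of the shared core tolerates variation, though a single flat step is thin evidence and a larger isopropyl may behave differently.

The expectation for compound 3 in this assay is therefore no change beyond the scatter, an estimated step of a 1.0-fold higher number from compound 2 to compound 3 (0.02 log units; within the scatter) from compound 2. Compound 3 is estimated at 1000 nM, with a range from 400 nM to 2500 nM.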

Compound 3, half-maximal inhibitory concentration: 689 nM
Estimate against measurement, compound 3: 1.5-fold (0.16 log units) above, and the stated range covers the measured number.
By their numbers in this assay, from the lowest: compounds 3, 1 and 2 (each within the scatter of the next).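

In this assay, isopropyl in place of methyl on a saturated chain carbon, two bonds along the chain from an aromatic carbon and an oxygen on a saturated carbon, gives a 1.4-fold lower number from compound 2 to compound 3 (0.14 log units; within the scatter) and so shows that three carbons can stand where one stood without a measurable effect on the result. Set against the straight hydroxyalkyl group, 1-hydroxy-1,3-dimethylbutyl in place of 3-hydroxypropyl on the aromatic carbon gives a 1.4-fold lower number from compound 1 to compound 3 (0.14 log units; within the scatter) and thus adds a second flat comparison, this time with a more heavily branched group than 1-hydroxy-1-methylpropyl, so all three compounds remain within the scatter of one another. No measurement is available that would explain why these numbers stay level.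

On these data alone, all three compounds keep an oxygen-bearing carbon chain on the aromatic carbon, so it remains open whether an amine, a carboxylic acid or a plain alkyl chain with no hydroxyl at that place would give a similar number. As far as these compounds go, it also remains open whether the same holds for a cyclohexyl ring or a much longer chain on the saturated chain carbon.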